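This account rests on a few compounds, and the source may have more. Where it says the series, first, only, none or still open, it means among the compounds named here.

Measured so far: compound 2, `CC(Oc1ccccc1OC1CC1)C1=NCCN1`, gives 676 nM in an assay on CHO cells for displacement of a labelled ligand from Alpha-2C adrenergic receptor (Homo sapiens); a higher number here means a weaker inhibitor, a lower number a stronger inhibitor; compound 1, `CC(C)Oc1ccccc1OC(C)C1=NCCN1`, gives 398 nM there.

Compound 2 has the higher of the two numbers, with compound 1 nearest at a 1.7-fold higher number from compound 1 to compound 2 (0.23 log units; within the scatter). Compound 3, `CC(Oc1ccccc1S(C)(=O)=O)C1=NCCN1`, differs from compound 2 by methylsulfonyl in place of cyclopropyloxy on an aromatic carbon. Among the compounds with values here, no measured step swaps an ether for a methylsulfonyl; the one step known, from compound 1 to compound 2, stayed within the scatter. A change this size on the ring is therefore expected to raise the number for compound 3 moderately, by about a 2.2-fold higher number from compound 2 to compound 3 (0.35 log units; beyond the scatter), with wide uncertainty. Compound 3 is estimated at 1500 nM, ranging from 400 nM to 6000 nM.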

Compound 3, inhibition constant: 3800 nM
Compound 3: the middle estimate sits 2.5-fold (0.40 log units) below what was measured, within the range that was stated.
By their numbers in this assay, from the lowest: compounds 1 and 2 (each within the scatter of the next); then compound 3.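

Where the two ethers on this aromatic carbon stayed within the scatter of each other, methylsulfonyl in place of cyclopropyloxy gives a 5.6-fold higher number from compound 2 to compound 3 (0.75 log units; beyond the scatter) in this assay. Methylsulfonyl in place of isopropoxy gives a 9.5-fold higher number from compound 1 to compound 3 (0.98 log units; beyond the scatter), so the number at this position does respond to the group placed there, and compound 3 is the weakest inhibitor of the three. Nothing available explains this rise.

Going by these compounds, whether an amine or a carboxylic acid on this aromatic carbon would stay near the ethers or rise as far as methylsulfonyl remains open. So does the effect of a longer alkoxy chain here.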